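Swapping fluoro for trifluoromethyl on a weak calcium channel series

This account rests on a few compounds, and the source may have more. Where it says the series, first, only, none or still open, it means among the compounds named here.

Measured compounds:
Compound 1 `CN(Cc1ccc(OCCCN)cc1)c1nc2ccc(Oc3ccc(C(F)(F)F)cc3)cc2s1` gives 283000 nM in an assay on SH-SY5Y cells for inhibition of Voltage-dependent N-type calcium channel subunit alpha-1B (Homo sapiens), read by FLIPR and calcium flux, with stated times of 600 s and 300 s, in the presence of a further agent that is not named here; on this read-out higher numbers stand for weaker inhibition and lower numbers for stronger inhibition.
Compound 2 `CN(Cc1ccc(OCCCN)cc1)c1nc2ccc(Oc3ccc(F)cc3)cc2s1` gives 98000 nM in this assay.
Compound 3 `N=C(N)NCCCOc1ccc(CNc2nc3ccc(Oc4ccc(F)cc4)cc3s2)cc1` gives 244000 nM in this assay.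

All three numbers are very high, so none of these compounds inhibits the channel strongly. Within the series, one change has been made already: trifluoromethyl in place of fluoro on an aromatic carbon, which gave a 2.9-fold higher number from compound 2 to compound 1 (0.46 log units; beyond the scatter). The difference between the core of compound 2 and the core of compound 3 is not broken down here. Compound 4 `N=C(N)NCCCOc1ccc(CNc2nc3ccc(Oc4ccc(C(F)(F)F)cc4)cc3s2)cc1` has not yet been measured; it differs from compound 3 by trifluoromethyl in place of fluoro on an aromatic carbon, the same change as before, since the surroundings described for both places read alike. Because a 2.9-fold higher number from compound 2 to compound 1 (0.46 log units; beyond the scatter) was modest, a step of similar size is expected, namely a 2.5-fold higher number from compound 3 to compound 4 (0.39 log units; beyond the scatter). Compound 4 is therefore estimated at 600000 nM, between 250000 nM and 1500000 nM, with a real chance that only a limit is reported.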

Compound 4, half-maximal inhibitory concentration: 167000 nM
The estimate for compound 4 lay 3.6-fold (0.56 log units) above the measured number; the whole stated range lies above it.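

In this assay, the swap of fluoro for trifluoromethyl gave a 1.5-fold lower number from compound 3 to compound 4 (0.16 log units; within the scatter), so on this core the change made no difference beyond the scatter. Set beside the earlier result, the same change did not carry over from one core to the other: the same change on two cores in this assay, a 2.9-fold higher number (0.46 log units; beyond the scatter) from compound 2 to compound 1 and a 1.5-fold lower number (0.16 log units; within the scatter) from compound 3 to compound 4, 4.2-fold (0.63 log units) apart, beyond the scatter of two such steps. Among these compounds, with only two pairs, this shows that the step on one core was a poor guide to the step on the other, but it does not show which part of the cores is responsible or how the change would behave on a further core.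

The compounds shown leave open whether the two cores also part ways when chloro, methoxy or nitrile takes the place of fluoro. Going by these compounds, all four numbers are very high, so it also remains open whether this holds among stronger inhibitors.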